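The source may hold more compounds than are shown below. What is called first, only, known or untested is meant among the compounds shown, and "the series" means these compounds.

Measured so far in a functional assay on U-87MG ATCC cells for cytotoxicity against U-87 MG (Homo sapiens), read by MTT assay, with a stated time of 24 h; a higher number here means a weaker inhibitor, a lower number a stronger inhibitor
compound 1 `COc1cc(CNC(=O)Nc2ccc([N+](=O)[O-])cc2)ccc1O` gives 98500 nM
compound 2 `COc1cc(CNC(=O)Nc2ccc(Cl)cc2)ccc1O` gives 92500 nM

Compound 2 stands level with compound 1: their two values lie within the usual scatter of repeated measurements, and neither can be called the stronger inhibitor. Compound 3 `COc1ccc(NC(=O)NCc2ccc(O)c(OC)c2)cc1` has not been measured yet. It keeps the shared core and carries methoxy in place of chloro on an aromatic carbon, para to a large group (methoxy in place of chloro on an aromatic carbon). Among the measured compounds shown here, only one measured step bears on this place: a 1.1-fold lower number from compound 1 to compound 2 (0.03 log units; within the scatter) in this assay with chloro in place of nitro, and that swap left the value inside the scatter. Going by this one step, no shift beyond the scatter is expected for methoxy, though a single step is thin evidence and the range must stay wide. The expected step (a 1.0-fold higher number from compound 2 to compound 3 (0.01 log units; within the scatter)) is therefore close to nothing. Compound 3 is expected at 95000 nM (estimated range 55000 nM to 160000 nM).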

Compound 3, half-maximal inhibitory concentration: > 100000 nM
Compound 3 ended at the assay's limit; the forecaster's own chance of this, stated with the estimate: 10%; middle value at least 1.0-fold (0.02 log units) away from the limit.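

In this assay compound 3 gives > 100000 nM, which is a limit of the assay and not a number. Of the three groups at this place, methoxy is the only one that leaves no exact value, but the two steps, an at least 1.0-fold higher number from compound 2 to compound 3 (0.03 log units; that floor lies within the scatter) and an at least 1.0-fold higher number from compound 1 to compound 3 (0.00 log units; that floor lies within the scatter), give only floors, so compound 3 may stand level with the other two or well apart from them. What this adds is that three different groups at this position, nitro, chloro and methoxy, have so far produced nothing stronger than values close to the top of what the test can read: the limit of > 100000 nM in this assay, at which 1 of the 3 values shown sits.

Going by these compounds, how far methoxy really differs from chloro or nitro stays open, since a limit offers no number to compare. Also open, on these data alone, is whether any group on this aromatic carbon can bring the value well down from that ceiling, for instance an amine, a carboxylic acid or a longer chain such as ethoxy in place of methoxy.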